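Trifluoromethyl for fluoro on the pendant phenyl ring

The source may report more compounds than this note shows. Statements on the series, on what has been measured and on what is new or still open speak of the compounds shown alone.

Measured so far:
compound 1 `CC(=O)Nc1ccc2oc(-c3cccc(F)c3)cc(=O)c2c1` — 240000 nM
compound 2 `CC(=O)Nc1ccc2oc(-c3ccc(F)cc3)cc(=O)c2c1` — 203000 nM
compound 3 `CC(=O)Nc1ccc2oc(-c3cccc(C(F)(F)F)c3)cc(=O)c2c1` — 10000 nM

Three compounds share one core and differ only in the phenyl ring attached to it. They were tested in an ADME assay on MT4 cells (Homo sapiens) for cytotoxicity, read by MTT assay, with a stated time of 4 days; a higher number here means that more compound is tolerated, a lower number that less compound is tolerated. Compound 1 gives 240000 nM and compound 2 gives 203000 nM in this assay; the two differ by 4-fluorophenyl in place of 3-fluorophenyl on an aromatic carbon, and the step of a 1.2-fold lower number from compound 1 to compound 2 (0.07 log units; within the scatter) is within the scatter, so no order between them can be read. Compound 3 carries trifluoromethyl in place of fluoro on an aromatic carbon and gives 10000 nM in this assay; the step of a 24-fold lower number from compound 1 to compound 3 (1.38 log units; beyond the scatter) is large and beyond the scatter.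

Compound 4 `CC(=O)Nc1ccc2oc(-c3ccc(C(F)(F)F)cc3)cc(=O)c2c1` is not yet measured. It differs from compound 2 by trifluoromethyl in place of fluoro on an aromatic carbon. Among the measured compounds shown here, this is the same kind of change as the one from compound 1 to compound 3, but not the same: in compound 3 the trifluoromethyl sits meta to a large group, in compound 4 para to a large group. Compound 2 is expected to take the step of a 23-fold lower number from compound 2 to compound 4 (1.35 log units; beyond the scatter) to compound 4, resting on the step of a 24-fold lower number from compound 1 to compound 3 (1.38 log units; beyond the scatter) seen for the same kind of change; the different place adds uncertainty. Compound 4 is therefore expected to give about 9000 nM in this assay, estimated between 3000 nM and 40000 nM.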

Compound 4, half-maximal cytotoxic concentration: 330000 nM
Estimate against measurement, compound 4: 37-fold (1.56 log units) below; the whole stated range lies below it.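

In this assay, trifluoromethyl in place of fluoro para to a large group gives a 1.6-fold higher number from compound 2 to compound 4 (0.21 log units; within the scatter), so this pair shows no readable difference. The same kind of change gave a large drop on the other pair, which means that its effect cannot simply be carried from one compound of this series to the next, even when the rest of the molecule is the same: the two results differ by more than the scatter: the same change on two cores in this assay, a 24-fold lower number (1.38 log units; beyond the scatter) from compound 1 to compound 3 and a 1.6-fold higher number (0.21 log units; within the scatter) from compound 2 to compound 4, 39-fold (1.59 log units) apart, beyond the scatter of two such steps. What this does not show is why the two steps part, as two pairs cannot separate the place of the trifluoromethyl from any other explanation, and they reveal nothing about which property of the group matters.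

As far as these compounds go, it remains open whether compound 3 or compound 4 is the better guide to how other compounds behave, as a single pair at each place cannot establish a trend. From the compounds shown here alone, it is also open whether a different group on the pendant phenyl ring, such as a chloro group, a methoxy group, an amine or a carboxylic acid, would depend on its place in the same way.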